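Shifting the fluorine on the aryl ester

A few compounds are considered here, and "the series" means these few. Any claim that something is new, unique, unknown or untested is made for them only; others in the source may bear on it.

Among the measured compounds shown here, in a functional assay on HeLa cells (Homo sapiens) for cytotoxicity, read by sulforhodamine B assay, with a stated time of 72 h (a lower number here means a stronger inhibitor, a higher number a weaker inhibitor), compound 2 `C=C1C(=O)O[C@@H]2CC(C)=C([C@@H](C)CCCOC(C)=O)[C@@H](OC(=O)c3ccccc3F)[C@H]12` gives 17000 nM as the lower of the two numbers so far, against compound 1 `C=C1C(=O)O[C@@H]2CC(C)=C([C@@H](C)CCCOC(C)=O)[C@@H](OC(=O)COc3ccc(C(C)=O)cc3)[C@H]12` at 43900 nM in the same read-out. Compound 3 `C=C1C(=O)O[C@@H]2CC(C)=C([C@@H](C)CCCOC(C)=O)[C@@H](OC(=O)c3cccc(F)c3)[C@H]12` keeps the shared core and carries 3-fluorophenyl in place of 2-fluorophenyl on a carbonyl carbon, the difference being 3-fluorophenyl in place of 2-fluorophenyl on a carbonyl carbon with the same atoms joined differently. For the measured compounds named here, the only measured step is a 2.6-fold lower number from compound 1 to compound 2 (0.41 log units; beyond the scatter) at that same place, modest and beyond the scatter. Going by the values given here, that step exchanges a different group, so no measured pair tests a move of the fluorine. Taking compound 2 at 17000 nM as the anchor, no step beyond the scatter is expected in this assay and no direction can be argued. The estimated change is a 1.1-fold higher number from compound 2 to compound 3 (0.02 log units; within the scatter) on present data. Compound 3 is expected at 18000 nM with an estimated range of 8000 nM to 40000 nM as a working figure.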

Compound 3, half-maximal inhibitory concentration: 11800 nM
For compound 3 the middle estimate is 1.5-fold (0.18 log units) above the measured one, within the range that was stated.
By their numbers in this assay, from the lowest: compounds 3 and 2 (each within the scatter of the next); then compound 1.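

Moving the fluorine, with 3-fluorophenyl in place of 2-fluorophenyl on a carbonyl carbon, gives a 1.4-fold lower number from compound 2 to compound 3 (0.16 log units; within the scatter) in this assay, so this first direct test of the fluorine's place separates neither compound from the other. The 3-fluorophenyl group also gives a 3.7-fold lower number from compound 1 to compound 3 (0.57 log units; beyond the scatter) when it replaces (4-acetylphenoxy)methyl, so the difference from compound 1 seen with 2-fluorophenyl holds for both fluorophenyl esters, though it remains modest. No supporting evidence bears on why these numbers fall as they do.

The compounds shown leave open how a plain phenyl, a 4-fluorophenyl or a 3-aminophenyl group would read at this carbonyl carbon. Going by these compounds, it also remains open whether a carboxylic acid on the aryl ring, or a longer chain before it, would move the number further than any step seen so far.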